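A few compounds are considered here, and "the series" means these few. Any claim that something is new, unique, unknown or untested is made for them only; others in the source may bear on it.

Compound 1 `Cc1cccc(COc2ccc3c(c2)[C@@H](O)CN(C)C3)c1` — > 50000 nM
Compound 2 `CN1Cc2ccc(OCc3cccc(Br)c3)cc2[C@@H](O)C1` — 60300 nM

In an ADME assay on Vero cells (Chlorocebus sabaeus) for cytotoxicity, read by sulforhodamine B assay, with a stated time of 72 h (a lower number here means a stronger inhibitor, a higher number a weaker inhibitor), compound 1 gives > 50000 nM, which is a limit of the assay rather than a number. Among the measured compounds shown here, compound 2 gives 60300 nM in this assay, and this is the only actual number among the two values shown. For the measured compounds named here, the single measured step, a step that the limit leaves unreadable from compound 1 to compound 2, cannot be read in size because of the limit of > 50000 nM in this assay, at which 1 of the 2 values shown sits. Compound 3 `COc1cccc(-c2cccc(COc3ccc4c(c3)[C@@H](O)CN(C)C4)c2)c1` differs from compound 2 by 3-methoxyphenyl in place of bromo on an aromatic carbon. Going by the values given here, no measured step with a readable size bears on that change, so the expectation rests on compound 2 alone and carries wide uncertainty. The step of a 2.0-fold lower number from compound 2 to compound 3 (0.30 log units; within the scatter) is an estimate only, leaning toward somewhat stronger inhibition. Compound 3 is therefore expected to give about 30000 nM in this assay, within an estimated range of 8000 nM to 80000 nM.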

Compound 3, half-maximal inhibitory concentration: 24300 nM
Compound 3: the middle estimate sits 1.2-fold (0.09 log units) above what was measured; low and high end bracket the measured number.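

In this assay, among the compounds shown here, replacing bromo with 3-methoxyphenyl gives a 2.5-fold lower number from compound 2 to compound 3 (0.39 log units; beyond the scatter), the first step at this position whose size can be read. The step is modest, so a group of 8 heavy atoms with its own aromatic ring, in place of a single bromine, shifts the number only a little. The step against methyl, an at least 2.0-fold lower number from compound 1 to compound 3 (0.31 log units; beyond the scatter), gives only a minimum size, as the value of compound 1 is a limit and not a number: the limit of > 50000 nM in this assay, at which 1 of the 3 values shown sits.

Going by these compounds, it remains open whether the lower number belongs to the added ring itself or to the methoxy group on it, a question that a plain phenyl at this position would address. Also open, on these data alone, is how an amine or a carboxylic acid on the added ring would shift the number.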